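The compounds below may be only part of what the source reports. "The series", "measured", "known", "first", "only" and "open" are said of these compounds alone.

Of the compounds shown here, three that share one core have numbers so far in an ADME assay on WI-38 cells (Homo sapiens) for cytotoxicity, read by MTT assay, with a stated time of 72 h; on this read-out lower numbers stand for stronger inhibition and higher numbers for weaker inhibition. Compound 1 (`O=C(CCc1cccc2c1B(O)OC2)Nc1ccccc1`) gives 30000 nM, compound 2 (`O=C(CCc1cccc2c1B(O)OC2)Nc1cccc(I)c1`) gives 71000 nM, and compound 3 (`O=C(CCc1cccc2c1B(O)OC2)Nc1cccc(-c2cccc(F)c2)c1`) gives 37000 nM. Compound 3 stands within the scatter of both others, as the steps show: a 1.2-fold higher number from compound 1 to compound 3 (0.09 log units; within the scatter) and a 1.9-fold lower number from compound 2 to compound 3 (0.28 log units; within the scatter). Within the data shown here, only one step among the three clears the scatter, and modestly: a 2.4-fold higher number from compound 1 to compound 2 (0.37 log units; beyond the scatter).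

Compound 4 (`O=C(CCc1cccc2c1B(O)OC2)Nc1cccc(-c2ccc(F)cc2)c1`) carries a single change from compound 3, with 4-fluorophenyl in place of 3-fluorophenyl on an aromatic carbon. Among the measured compounds shown here, no measured step makes this exact swap. The closest evidence is compound 3 itself, where adding the whole 3-fluorophenyl group to compound 1 stayed within the scatter: a 1.2-fold higher number from compound 1 to compound 3 (0.09 log units; within the scatter). A step beyond the scatter in this assay is therefore not expected, and neither direction is favoured. The estimated step is a 1.0-fold higher number from compound 3 to compound 4 (0.01 log units; within the scatter). The expected value for compound 4 is 38000 nM, with an estimated range from 18000 nM to 75000 nM.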

Compound 4, half-maximal inhibitory concentration: 4100 nM
Estimate against measurement, compound 4: 9.3-fold (0.97 log units) above; measured number below the stated range.
By their numbers in this assay, from the lowest: compound 4; then compounds 1, 3 and 2 (each within the scatter of the next, the first and the last beyond it).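

In this assay, the same atoms joined differently give a 9.0-fold lower number from compound 3 to compound 4 (0.96 log units; beyond the scatter) and so the place of the fluorine on this phenyl group matters, although adding 3-fluorophenyl to compound 1 had stayed within the scatter. The gain also holds against the other two compounds, with a 7.3-fold lower number from compound 1 to compound 4 (0.86 log units; beyond the scatter) as well as a 17-fold lower number from compound 2 to compound 4 (1.24 log units; beyond the scatter) on record, which leaves compound 4 with the lowest number of the four and the strongest inhibition among them. Nothing available explains why moving one fluorine has so large an effect.

On these data alone, it remains open whether fluorine itself is needed or whether any group in that place would do, which plain phenyl or 4-chlorophenyl could test. The compounds shown also leave open whether 4-fluorophenyl would give a similar step on a different chain or core.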